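The source may report more compounds than this note shows. Statements on the series, on what has been measured and on what is new or still open speak of the compounds shown alone.

Working notes, read-out in an ADME assay on microsomes from liver (Mus musculus) for metabolic stability, read by LC-MS, using NADPH, with a stated time of 60 min, tested at 1 uM (a higher number here means that the compound lasts longer, a lower number that the compound disappears faster), as follows
- compound 1 `O=C(O)CC1Cc2ccc(-c3cc(F)cc(OC(F)F)c3)cc2N1S(=O)(=O)c1cccc(C(F)(F)F)c1` gives 1.88 h as half-life
- compound 2 `O=C(O)CCC1Cc2ccc(-c3cc(F)cc(OC(F)F)c3)cc2N1S(=O)(=O)c1cccc(C(F)(F)F)c1` gives 1.02 h as half-life

Within the data shown here, the only measured step is a 1.8-fold lower number from compound 1 to compound 2 (0.27 log units; within the scatter) and it puts carboxymethyl in place of carboxy, so compound 2 stands level with compound 1 within the scatter. The step under review leads to compound 3 `O=C(O)C1CN(C(=O)CC2Cc3ccc(-c4cc(F)cc(OC(F)F)c4)cc3N2S(=O)(=O)c2cccc(C(F)(F)F)c2)C1` with the difference (3-carboxyazetidin-1-yl)carbonyl in place of carboxymethyl on a saturated chain carbon bound to a saturated ring carbon in which (3-carboxyazetidin-1-yl)carbonyl stands in place of carboxymethyl on a saturated chain carbon bound to a saturated ring carbon. Among the measured compounds shown here, no measured compound carries a four-membered non-aromatic ring. For the measured compounds named here, with a 1.8-fold lower number from compound 1 to compound 2 (0.27 log units; within the scatter) as the sole guide at this place, no shift beyond the scatter is expected in this assay and the direction stays open. The estimated step is a 1.5-fold higher number from compound 2 to compound 3 (0.17 log units; within the scatter) and it is expected to stay within the scatter. For compound 3 the expected half-life is 1.5 h with an estimated range from 0.6 h to 4 h as the span.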

Compound 3, half-life: 1.1 h
Compound 3: the middle estimate sits 1.4-fold (0.13 log units) above what was measured; low and high end bracket the measured number.
By their numbers in this assay, from the lowest: compounds 2, 3 and 1 (each within the scatter of the next).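

In this assay the (3-carboxyazetidin-1-yl)carbonyl group on a saturated chain carbon bound to a saturated ring carbon gives a 1.1-fold higher number from compound 2 to compound 3 (0.03 log units; within the scatter) and, read against the parent acid, 3-carboxyazetidin-1-yl in place of hydroxy on a carbonyl carbon gives a 1.7-fold lower number from compound 1 to compound 3 (0.23 log units; within the scatter). Compounds 1 and 2 differed only by carboxymethyl against carboxy, whereas compound 3 shows that this position also accepts a four-membered non-aromatic ring with one hetero atom, together with a second carbonyl, with no shift beyond the scatter. No data bear on the reason for this result.

From the compounds shown here alone, all three compounds end in a carboxylic acid, so it stays open how an amine or a primary amide at that end would read. Going by these compounds, whether a piperidine ring carrying the carboxy group would behave like the azetidine also stays open.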